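Methoxy in place of fluoro on compound 2

A few compounds are considered here, and "the series" means these few. Any claim that something is new, unique, unknown or untested is made for them only; others in the source may bear on it.

Compound 1 `COc1ccc(C(=O)CSc2nc(Cc3c(Cl)cccc3Cl)c(C(C)C)c(=O)[nH]2)cc1`: > 14000 nM (a limit)
Compound 2 `CC(C)c1c(Cc2c(F)cccc2F)nc(SCC(=O)c2ccc(F)cc2)[nH]c1=O`: > 58000 nM (a limit)

In an ADME assay on MT4 cells (Homo sapiens) for cytotoxicity, read by MTT assay (on this read-out higher numbers stand for lower toxicity in this test and lower numbers for higher toxicity in this test), compound 2 gives > 58000 nM, which is a limit of the assay and not a number. Compound 1 also gives only a limit, > 14000 nM. Compound 2 therefore has no exact position on this scale.

Compound 3 `COc1ccc(C(=O)CSc2nc(Cc3c(F)cccc3F)c(C(C)C)c(=O)[nH]2)cc1` differs from compound 2 in one place: methoxy in place of fluoro on an aromatic carbon. Methoxy stands in place of fluoro on an aromatic carbon, para to a large group, so 4-fluorophenyl becomes 4-methoxyphenyl.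

For the measured compounds named here, no two measured compounds differ in only one place, so no measured step can serve as a guide. Compound 1 already carries the 4-methoxyphenyl group, and its result in this assay is the limit > 14000 nM. This gives no sign of a large change. The expected step of an at least 1.4-fold lower number from compound 2 to compound 3 (0.16 log units; that floor lies within the scatter) is no larger than the usual scatter, with no clear direction. The assay may well report only a limit again. For compound 3 the estimated value is 40000 nM, with an expected range of 10000 nM to 100000 nM.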

Compound 3, half-maximal cytotoxic concentration: 33000 nM
For compound 3 the middle estimate is 1.2-fold (0.08 log units) above the measured one; low and high end bracket the measured number.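

In this assay, for the compounds shown here, compound 3 is the first of the three compounds to give an actual number, 33000 nM, so the series now has one exact point on this scale instead of limits alone. Replacing 4-fluorophenyl with 4-methoxyphenyl, on an aromatic carbon para to a large group, gives an at least 1.7-fold lower number from compound 2 to compound 3 (0.24 log units; that floor lies within the scatter); this floor alone does not establish a real change at this position, but the exact value of compound 3 shows what the methoxy compound reads rather than leaving it as a limit. The step between compound 1 and compound 3 cannot be read, as compound 1 gives only a limit: the limit of > 14000 nM in this assay, at which 1 of the 3 values shown sits.

From the compounds shown here alone, only fluoro and methoxy appear at this position, so how an amine or a carboxylic acid placed there would read in this assay remains open. Also open, going by these compounds, are the true size of the step from fluoro to methoxy and whether 2,6-difluorophenyl and 2,6-dichlorophenyl differ at all in this test.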